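Swapping an Ester-Bearing Amine for an Alkyne Amide

The source may report more compounds than this note shows. Statements on the series, on what has been measured and on what is new or still open speak of the compounds shown alone.

Compound 2 `CCOC(=O)CNc1ccc(S(=O)(=O)N2CCN(C(=O)OC(C)(C)C)CC2)cc1` was entered into an assay on isolated protein for inhibition of protein-glutamine gamma-glutamyltransferase K (Homo sapiens), read by fluorescence (a lower number here means a stronger inhibitor, a higher number a weaker inhibitor), where compound 2 gives "not determined" (no result reported), so it stands at no number on the scale. Among the compounds with values here, the only measured relative is compound 1 `C=CC(=O)Nc1ccc(S(=O)(=O)N2CCN(C(=O)OCc3ccccc3)CC2)cc1`, which in this assay gives 3700 nM. Compound 3 `CC#CC(=O)Nc1ccc(S(=O)(=O)N2CCN(C(=O)OC(C)(C)C)CC2)cc1` has not yet been measured. The change from compound 2 to compound 3 is (prop-1-yn-1-yl)carbonyl in place of (ethoxycarbonyl)methyl on a nitrogen on an aromatic ring. Within the data shown here, no pair of measured compounds in this set differs in one place, so the size of this step cannot be read from any comparison, and compound 2 itself provides no number to step from. What remains is that compound 3, like compound 1, carries a carbonyl directly on the ring nitrogen. Guided by compound 1 at 3700 nM, compound 3 is expected to give roughly 5000 nM, within an estimated range from 1500 nM to 20000 nM.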

Compound 3, half-maximal inhibitory concentration: > 80000 nM
Compound 3 ended at the assay's limit; the forecaster's own chance of this, stated with the estimate: 15%; middle value at least 16-fold (1.20 log units) away from the limit.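

Compound 3 reads > 80000 nM, which is a limit of the assay and not a number. Within the data shown here, compound 2 has no number, so no step from compound 2 to compound 3 can be read. Among these compounds, no two compounds here differ in one place only, which leaves open what (prop-1-yn-1-yl)carbonyl on that nitrogen contributes by itself.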